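Vinyl for Methylpyrazolyl on a Shared Trimethoxyphenyl Core

A few compounds are considered here, and "the series" means these few. Any claim that something is new, unique, unknown or untested is made for them only; others in the source may bear on it.

Measured so far in a functional assay on MCF7 cells (Homo sapiens) for inhibition, read by CCK-8 assay, with a stated time of 48 h; on this read-out lower numbers stand for stronger inhibition and higher numbers for weaker inhibition:
compound 1, `Cc1ccc(-c2cc3nccc(-c4ccc(F)cc4)n3n2)cc1`: > 10000 nM.
compound 2, `COc1cc(-c2ccnc3cc(-c4ccc(-c5cnn(C)c5)cc4)nn23)cc(OC)c1OC`: 274 nM.
compound 3, `COc1cc(-c2ccnc3cc(-c4cn(C(=O)OC(C)(C)C)c5ccccc45)nn23)cc(OC)c1OC`: 268 nM.

This assay reports for compound 1 only a limit, > 10000 nM, and not a number; compound 1 sits at the limit of > 10000 nM in this assay, at which 1 of the 3 values shown sits. Among the two numbers, compound 2 gives 274 nM in this assay, the higher of the two, while compound 3 gives 268 nM; the gap between them lies within the scatter, so the two cannot be ordered.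

Compound 4, `C=Cc1ccc(-c2cc3nccc(-c4cc(OC)c(OC)c(OC)c4)n3n2)cc1`, has not yet been measured. It differs from compound 2 by vinyl in place of 1-methyl-1H-pyrazol-4-yl on an aromatic carbon. Going by the values given here, no measured pair shows this same change, so no step can be read directly from the data; compounds 2 and 3 both carry the trimethoxyphenyl group that compound 4 keeps, and both give similar numbers. The step is expected to be modest and toward weaker inhibition, estimated as a 2.2-fold higher number from compound 2 to compound 4 (0.34 log units; beyond the scatter). Compound 4 is expected to give about 600 nM in this assay, within a range from 150 nM to 2500 nM.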

Compound 4, half-maximal inhibitory concentration: 193 nM
Estimate against measurement, compound 4: 3.1-fold (0.49 log units) above; measured number inside the range.
By their numbers in this assay, from the lowest: compounds 4, 3 and 2 (each within the scatter of the next). At a limit, above all of these: compound 1.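

In this assay, replacing 1-methyl-1H-pyrazol-4-yl with vinyl gives a 1.4-fold lower number from compound 2 to compound 4 (0.15 log units; within the scatter), so the two compounds cannot be told apart. Going by these compounds alone, this shows what the earlier compounds could not: on this aromatic carbon, para to a large group, a substituent of 2 heavy atoms with no ring and no hydrogen-bond acceptors serves as well in this assay as one of 6 heavy atoms with a five-membered aromatic ring and 2 hydrogen-bond acceptors, so that ring and those acceptors are not required to reach this level of inhibition. Nothing among the data shown gives a reason for this result.

On these data alone, it remains open whether an amine or a carboxylic acid on the same aromatic carbon would keep a number of this size. As far as these compounds go, whether a longer chain in place of vinyl would do so also remains open.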